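A few compounds are considered here, and "the series" means these few. Any claim that something is new, unique, unknown or untested is made for them only; others in the source may bear on it.

Three compounds have been measured in a functional assay on the whole organism (Tail, strain ICR) with Mus musculus as the target, in the tail flick test, with a stated time of 150 min, at a dose of 25 umol/kg by the oral route; a higher number here means a stronger effect of the compound at the dose given, a lower number a weaker effect:

compound 1, `CSCC[C@H](NC(=O)CN(c1nc(Cl)nc2[nH]cnc12)C1CC1)C(=O)OCc1ccccc1`, giving 17.6%
compound 2, `CC(C)C[C@H](NC(=O)CN(c1nc(Cl)nc2[nH]cnc12)C1CC1)C(=O)OCc1ccccc1`, giving 5.26%
compound 3, `CSCC[C@H](NC(=O)CN(c1nc(Cl)nc2[nH]cnc12)C1CC1)C(=O)O`, giving 4.14%

Compound 3 has the lowest of the three numbers. Its nearest neighbour is compound 2, whose number sits within the usual scatter of it, so the two cannot be told apart; the furthest is compound 1, and the step of a number 13.5 percentage points lower from compound 1 to compound 3 (beyond the scatter) lies beyond the scatter. That step swaps a benzyl for a hydrogen on the oxygen next to the carbonyl group.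

Compound 4, `O=C(O)CNC(=O)CN(c1nc(Cl)nc2[nH]cnc12)C1CC1`, is not yet measured in this assay. It differs from compound 3 in one place: hydrogen in place of 2-(methylsulfanyl)ethyl on a saturated chain carbon bound to an amide-type nitrogen and a carbonyl carbon. The measured step that bears most on this is a number 12.3 percentage points lower from compound 1 to compound 2 (beyond the scatter), where the same side chain was altered rather than removed. That change already cost a modest amount, so taking the side chain away altogether gives no reason to expect a rise. Compound 3 sits near the bottom of the range, however, so there is little room left for a fall beyond the scatter.

The expected step is therefore a number 1.1 percentage points lower from compound 3 to compound 4 (within the scatter). Compound 4 is estimated at 3%, between 0% and 10%.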

Compound 4, a percentage reported as activity, at one dose (the size of the read-out at that dose, not a potency): 9.08%
For compound 4 the middle estimate is 6.1 percentage points below the measured one; the measured number falls inside the stated range.
By their numbers in this assay, from the lowest: compounds 3, 2, 4 and 1 (each within the scatter of the next, the first and the last beyond it).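

In this assay, replacing 2-(methylsulfanyl)ethyl with hydrogen on the saturated chain carbon bound to an amide-type nitrogen and a carbonyl carbon gives a number 4.9 percentage points higher from compound 3 to compound 4 (within the scatter), so among these two free carboxylic acids, the side chain makes no difference that can be told from ordinary assay noise. The earlier compounds shown here showed only that this position can matter when the benzyl ester is present, with a number 12.3 percentage points lower from compound 1 to compound 2 (beyond the scatter) when one side chain was exchanged for another, so the new pair adds a case in which even losing the whole chain leaves no readable change. No measurement here explains this result, and it remains an observation from a single pair.

The compounds shown leave open whether removing the side chain would also leave the number unchanged with the benzyl ester in place of the free acid. They also leave open how a methyl group, or a longer chain ending in an amine, would read at this same carbon.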